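Working notes: the step from compound 3 to compound 4

This account rests on a few compounds, and the source may have more. Where it says the series, first, only, none or still open, it means among the compounds named here.

Compound 1 `CCC1=C(O)c2c(oc(-c3ccc(CC)cc3)cc2=O)C(CC)(CC)C1=O`: 21.9 uM
Compound 2 `CCCc1ccc(-c2cc(=O)c3c(o2)C(CC)(CC)C(=O)C(CC)=C3O)cc1`: > 53 uM (a limit, not a number)
Compound 3 `CCOc1ccc(-c2cc(=O)c3c(o2)C(CC)(CC)C(=O)C(CC)=C3O)cc1`: > 52.4 uM (a limit, not a number)

In a functional assay on KB cells (Homo sapiens) for antiproliferative activity, read by sulforhodamine B assay, with a stated time of 3 days (on this read-out lower numbers stand for an effect already at smaller amounts and higher numbers for an effect only at larger amounts of compound), compound 3 has only a limit, > 52.4 uM. Compound 2 is also known only as a limit. Compound 1 is the only one of the three with a number, 21.9 uM.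

Compound 4 `CCC1=C(O)c2c(oc(-c3cccc(C)c3)cc2=O)C(CC)(CC)C1=O` carries 3-methylphenyl in place of 4-ethoxyphenyl on an aromatic carbon next to the ring oxygen: 3-methylphenyl in place of 4-ethoxyphenyl on an aromatic carbon. Going by the values given here, no measured step makes this exact change. The nearest evidence is an at least 2.3-fold higher number from compound 1 to compound 3 (0.37 log units; beyond the scatter) and an at least 2.4-fold higher number from compound 1 to compound 2 (0.38 log units; beyond the scatter). Both lie beyond the scatter and both give only a minimum size. In addition, a step that the two limits leave unreadable from compound 2 to compound 3, so it adds nothing on size.

The group entering compound 4 is neither of those carried by compound 2 and compound 3, so a return towards compound 1 at 21.9 uM is expected, though not with confidence given so few compounds. A modest move to a lower number is therefore expected, and the estimated step is an at least 1.8-fold lower number from compound 3 to compound 4 (0.27 log units; that floor lies within the scatter). A further limit in this assay remains quite possible. For compound 4 the estimate is 28 uM, with an expected range of 12 uM to 60 uM.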

Compound 4, concentration for half-maximal effect: 49.7 uM
Estimate against measurement, compound 4: 1.8-fold (0.25 log units) below; measured number inside the range.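

In this assay, the group on the aromatic carbon next to the ring oxygen now has a second readable result: there is a 2.3-fold higher number from compound 1 to compound 4 (0.36 log units; beyond the scatter), so the 3-methylphenyl group sits beyond the scatter from the 4-ethylphenyl group. Going by these compounds alone, this shows that a measured number at this position is not confined to compound 1, although compound 1 remains the only compound with a number clearly lower than that of compound 4. The comparisons with the two limits add little: there is an at least 1.0-fold lower number from compound 3 to compound 4 (0.02 log units; that floor lies within the scatter) and an at least 1.0-fold lower number from compound 2 to compound 4 (0.02 log units; that floor lies within the scatter), and with both floors within the scatter, 3-methylphenyl cannot be placed in order against 4-ethoxyphenyl or 4-propylphenyl.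

Relative to compound 1, compound 4 differs both in where the alkyl group stands on the phenyl ring and in the length of that group, and the compounds shown do not separate these two changes; 4-methylphenyl and 3-ethylphenyl would do so. Also open, on these data alone, is how this position responds to a group of another kind, such as an amine or a carboxylic acid on the phenyl ring.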